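From Cyclohexyl to 4-Nitrophenyl: Expecting Little Change

The compounds below may be only part of what the source reports. "The series", "measured", "known", "first", "only" and "open" are said of these compounds alone.

Of the compounds shown here, two from this series have been measured in a functional assay on A549 cells (Homo sapiens) for inhibition, read by XTT assay, with a stated time of 48 h; on this read-out lower numbers stand for stronger inhibition and higher numbers for weaker inhibition. Compound 1 `C=C(C(=O)c1ccc(OC)cc1)C(OC(=O)c1ccccc1)c1ccccc1F` gives 73700 nM in this assay, and compound 2 `C=C(C(=O)c1ccc(OC)cc1)C(OC(=O)c1ccccc1)C1CCCCC1` gives 62100 nM. Going by the values given here, the only step between them, a 1.2-fold lower number from compound 1 to compound 2 (0.07 log units; within the scatter), is within the scatter, so the two numbers cannot be told apart. Among the compounds with values here, compound 2 has the lowest of the two numbers, but its only neighbour, compound 1, sits within the scatter of it.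

Compound 3 `C=C(C(=O)c1ccc(OC)cc1)C(OC(=O)c1ccccc1)c1ccc([N+](=O)[O-])cc1` differs from compound 2 in one place: 4-nitrophenyl in place of cyclohexyl on a saturated chain carbon bound to a double-bonded chain carbon and an oxygen next to a carbonyl group. Within the data shown here, the one measured step that bears on this, from compound 1 to compound 2, exchanged a 2-fluorophenyl for a cyclohexyl at the same carbon and moved the number only within the scatter. Putting an aromatic ring back at that position, now carrying a nitro group, is therefore expected to give no step beyond the scatter in this assay, and compound 3 is expected to sit near compound 2, with the step of a 1.2-fold lower number from compound 2 to compound 3 (0.09 log units; within the scatter). The estimate for compound 3 is 50000 nM, with a range from 15000 nM to 150000 nM.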

Compound 3, half-maximal inhibitory concentration: 66600 nM
Compound 3: the middle estimate sits 1.3-fold (0.12 log units) below what was measured; the measured number falls inside the stated range.
By their numbers in this assay, from the lowest: compounds 2, 3 and 1 (each within the scatter of the next).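

In this assay, the exchange of cyclohexyl for 4-nitrophenyl on the saturated chain carbon bound to a double-bonded chain carbon and an oxygen next to a carbonyl group gives only a small step (a 1.1-fold higher number from compound 2 to compound 3 (0.03 log units; within the scatter)), and the exchange of 2-fluorophenyl for 4-nitrophenyl at the same carbon gives another (a 1.1-fold lower number from compound 1 to compound 3 (0.04 log units; within the scatter)). The three groups therefore cannot be told apart at this position in this read-out, even though 4-nitrophenyl is the larger group, carries hydrogen-bond acceptors that cyclohexyl lacks, and has an aromatic ring where cyclohexyl has a non-aromatic one. Nothing available here speaks to why the number stays the same across these groups.

As far as these compounds go, all three groups at this carbon are six-membered rings, so it remains open whether an amine, a carboxylic acid or a longer open chain in that place would give a step beyond the scatter. From the compounds shown here alone, it also remains open whether a change elsewhere in the shared core, such as replacing the methoxy group or the benzoate, would move the number more than any exchange at this carbon has so far.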